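Ring Size at the Amide Carbonyl of a Shared Core

The source may report more compounds than this note shows. Statements on the series, on what has been measured and on what is new or still open speak of the compounds shown alone.

Measured so far:
compound 1 `CC(C)(C)C(=O)N1CCCn2nc(COc3ccccc3)cc21` gives 64%
compound 2 `O=C(C1CCC1)N1CCCn2nc(COc3ccccc3)cc21` gives 41%
compound 3 `O=C(C1CCCC1)N1CCCn2nc(COc3ccccc3)cc21` awaits measurement

Within the data shown here, in a functional assay on HEK293 cells for positive allosteric modulation of metabotropic glutamate receptor 5 (Homo sapiens), read by calcium flux (on this read-out higher numbers stand for larger maximal responses and lower numbers for smaller maximal responses), compound 2 stands lowest of the two numbers known; its nearest neighbour is compound 1, which lies higher, and the only step recorded is a number 23 percentage points lower from compound 1 to compound 2 (beyond the scatter), with cyclobutyl in place of tert-butyl on a carbonyl carbon. Compound 3 differs from compound 2 in one place, (cyclopentyl in place of cyclobutyl on a carbonyl carbon).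

That single step from compound 1 to compound 2 is the only one that bears on the move to compound 3, and it shows that a change of the group on the carbonyl carbon can shift the maximal response by a modest amount beyond the scatter. Whether a larger ring recovers part of that response or leaves it where it is cannot be read from two points; the account therefore expects only a small step, if any, in this assay. The expected step is a number 9 percentage points higher from compound 2 to compound 3 (within the scatter), and for compound 3 the estimate is 50%, in the range 30% to 70%.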

Compound 3, largest response reached (reported as percent of maximum), in percent of the reference or control that the assay uses: 41%
Compound 3: the middle estimate sits 9 percentage points above what was measured, and the stated range covers the measured number.
By their numbers in this assay, from the lowest: compounds 2 and 3 (each within the scatter of the next); then compound 1.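

In this assay, the cyclobutyl and cyclopentyl amides cannot be told apart: enlarging the ring on the carbonyl carbon from a four-membered to a five-membered carbon ring gives no change at the digits printed from compound 2 to compound 3 (within the scatter), so the extra ring carbon does not recover the response lost from the tert-butyl amide. The gap to tert-butyl therefore holds for both rings, with a number 23 percentage points lower from compound 1 to compound 3 (beyond the scatter) matching a number 23 percentage points lower from compound 1 to compound 2 (beyond the scatter), and among these three compounds the tert-butyl amide alone stands apart, while the two rings share a single level. Nothing available here bears on why the tert-butyl group differs from either ring or why ring size makes no difference.

Going by these compounds, whether this level holds for all ring sizes remains open, since a cyclopropyl or a cyclohexyl group on the same carbonyl carbon could fall on either side of it. On these data alone, it is also open whether the higher response belongs to the branching of tert-butyl as such, which an isopropyl group or a 1-methylcyclobutyl group at this place would help to separate from ring size.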